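Thiophen-2-yl to 2,6-difluorophenyl on the shared core

The source may hold more compounds than are shown below. What is called first, only, known or untested is meant among the compounds shown, and "the series" means these compounds.

Compound 1 `CC1(C)C=C(n2ccccc2=O)c2cc(C(=O)c3cccs3)ccc2O1`: 6.4
Compound 2 `CC1(C)C=C(n2ccccc2=O)c2cc(C(=O)c3ccccc3F)ccc2O1`: 7.08
Compound 3 `CC1(C)C=C(n2ccccc2=O)c2cc(C(=O)c3ccccc3C(F)(F)F)ccc2O1`: 6.76

In a functional assay (aorta) with Rattus norvegicus as the target (a higher number here means a more potent compound, by a factor of ten per unit of this negative logarithm, a lower number a less potent compound), compound 1 stands lowest of the three measured compounds. The unmeasured compound 4 `CC1(C)C=C(n2ccccc2=O)c2cc(C(=O)c3c(F)cccc3F)ccc2O1` differs from compound 1 by 2,6-difluorophenyl in place of thiophen-2-yl on a carbonyl carbon.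

Among the measured compounds shown here, two measured steps bear on this change. Both replace thiophen-2-yl with a fluorinated phenyl on the carbonyl carbon: a number 0.68 log units higher from compound 1 to compound 2 (beyond the scatter) and a number 0.36 log units higher from compound 1 to compound 3 (beyond the scatter). Between those two phenyl variants, a number 0.32 log units lower from compound 2 to compound 3 (beyond the scatter). The change to compound 4 most resembles the first of these, with a second fluoro added, so a modest rise in this assay is expected, roughly a number 0.60 log units higher from compound 1 to compound 4 (beyond the scatter). Compound 4 is therefore estimated at 7, with a likely range from 6.5 to 7.5.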

Compound 4, logarithm of the reciprocal of the active concentration, log(1/C): 6.97
Compound 4: middle estimate off by 0.03 log units, on the high side, within the range that was stated.
By their numbers in this assay, from the lowest: compound 1; then compounds 3, 4 and 2 (each within the scatter of the next, the first and the last beyond it).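

In this assay, 2,6-difluorophenyl on the carbonyl carbon holds a clear gain over thiophen-2-yl, a number 0.57 log units higher from compound 1 to compound 4 (beyond the scatter). Adding the second fluoro gives a compound that cannot be told apart from its single-fluoro partner, a number 0.11 log units lower from compound 2 to compound 4 (within the scatter). Compound 4 also cannot be separated from the trifluoromethyl compound, a number 0.21 log units higher from compound 3 to compound 4 (within the scatter), even though compound 2 and compound 3 do differ beyond the scatter.

Nothing shown explains why these fluorinated phenyl groups stand above thiophen-2-yl. On these data alone, whether a phenyl carrying a methoxy or an amine would reach the same level remains open.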